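From Compound 2 to Compound 3 at a Carbonyl Carbon

The compounds below may be only part of what the source reports. "The series", "measured", "known", "first", "only" and "open" are said of these compounds alone.

In a functional assay on PC-3 cells (Homo sapiens) for antiproliferative activity, read by MTT assay, with a stated time of 72 h (a lower number here means a stronger inhibitor, a higher number a weaker inhibitor), compound 1 (`CCn1c(C(=O)NCCC(=O)OC)ccc1C(CC)(CC)c1ccc(C#CC(O)(CC)CC)c(C)c1`) gives 36300 nM. Compound 2 (`CCn1c(C(=O)On2nnc3ccccc32)ccc1C(CC)(CC)c1ccc(C#CC(O)(CC)CC)c(C)c1`) stands at the limit of > 50000 nM in this assay, at which 1 of the 2 values shown sits, and its reading of > 50000 nM is a limit and not a number.

Compound 3 (`CCn1c(C(=O)N[C@H](C(=O)O)C(C)C)ccc1C(CC)(CC)c1ccc(C#CC(O)(CC)CC)c(C)c1`) departs from compound 2 on a carbonyl carbon, with a group of 8 heavy atoms and no ring taking the place of the two-ring group: a group of 8 heavy atoms (5 carbon, 1 nitrogen, 2 oxygen; no ring) in place of a group of 10 heavy atoms (6 carbon, 3 nitrogen, 1 oxygen; one five-membered aromatic ring with 3 hetero atoms, one six-membered aromatic ring of carbon only), on a carbonyl carbon.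

Among the compounds with values here, one measured step bears on this change, and it concerns the same carbonyl carbon. It is an at least 1.3-fold higher number from compound 1 to compound 2 (0.13 log units; that floor lies within the scatter), so it gives only a floor and no firm size. Compound 3 resembles compound 1 in carrying a group without a ring at this place, and compound 1 gives 36300 nM, so a reading in the same region is expected. The expected shift in this assay is small and towards a lower number, and it is estimated as an at least 1.5-fold lower number from compound 2 to compound 3 (0.19 log units; that floor lies within the scatter). A reading that is again only a limit would not be surprising. For compound 3 the estimated value is 32000 nM, with an expected range from 11000 nM to 65000 nM.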

Compound 3, half-maximal inhibitory concentration: 5000 nM
Compound 3: the middle estimate sits 6.4-fold (0.81 log units) above what was measured; the measured number lies below the stated range.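

In this assay, the change on the carbonyl carbon gives an at least 10-fold lower number from compound 2 to compound 3 (1.00 log units; beyond the scatter), so this place now shows a step beyond the scatter, where the earlier step gave only a floor within it. That size is itself only a floor, and the reading of compound 2 is a limit and not a number: the limit of > 50000 nM in this assay, at which 1 of the 3 values shown sits.

The two groups without a ring also differ clearly, with 1-carboxy-2-methylpropyl in place of 2-(methoxycarbonyl)ethyl on the amide-type nitrogen giving a 7.3-fold lower number from compound 1 to compound 3 (0.86 log units; beyond the scatter), so having no ring at this place does not alone set the reading among these compounds.

The compounds shown leave open which feature of the 1-carboxy-2-methylpropyl group goes with the lower number, as its carboxylic acid, its branched chain and its defined stereocentre all enter together. As far as these compounds go, a methyl ester on the same branched chain, the opposite stereocentre, or an unbranched chain carrying the carboxylic acid would each separate these features, and how far the number can fall with a longer chain at this place also remains open.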